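Dienones with a hydroxyphenyl ketone: removing the methoxy

The source may report more compounds than this note shows. Statements on the series, on what has been measured and on what is new or still open speak of the compounds shown alone.

Working notes on a short set of open-chain dienones carrying a hydroxyphenyl ketone. Compound 1 `O=C(/C=C(O)/C=C/c1ccccc1)c1ccccc1O`, compound 2 `O=C(/C=C/C=C/c1ccc([N+](=O)[O-])cc1)c1ccccc1O` and compound 3 `COc1ccc(/C=C/C=C/C(=O)c2ccccc2O)cc1` have been tested in an in vitro assay on cells for inhibition of Amine oxidase [flavin-containing] A (Homo sapiens), read by Amplex Red, with a stated time of 15 min, tested at 100 uM; on this read-out lower numbers stand for less inhibition and higher numbers for more inhibition at the one concentration tested (going by the name of the read-out). Compound 1 is recorded as "not active" (no number reported). Compound 2 is likewise recorded as "not active" (no number reported). Among the measured compounds shown here, compound 3 gives 40%, the only figure in the set, so it stands as the single numerical reference point; the other two entries give no number to compare against, and the size of no measured step can be stated.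

Compound 4 `O=C(/C=C/C=C/c1ccccc1)c1ccccc1O` has not yet been run in this assay. It differs from compound 3 as follows: hydrogen in place of methoxy on an aromatic carbon. For the measured compounds named here, no measured pair shares this change, so the expectation rests on the single reading of compound 3. The step is expected to be a modest fall in inhibition, a number 15 percentage points lower from compound 3 to compound 4 (beyond the scatter). Because compound 1 is recorded as "not active" (no number reported) and compound 2 as "not active" (no number reported), a readout without a number would not be surprising for compound 4 either. Compound 4 is estimated at 25%, with a range from 5% to 45%.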

Compound 4, a percentage reported as inhibition, at one concentration (the size of the read-out at that concentration, not a potency): "not active" (no number reported)
No number was reported for compound 4; there is nothing to compare the estimate with.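

No step can be read from compound 3 to compound 4: in this assay compound 3 gives 40% while compound 4 gives "not active" (no number reported) and so offers no number to compare. The compounds shown leave open how much inhibition the methoxy accounts for. No supporting data bear on this result.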